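Swapping a dichlorinated ring for a monofluorinated one

The compounds below may be only part of what the source reports. "The series", "measured", "known", "first", "only" and "open" are said of these compounds alone.

Compound 3 `COc1cc(C(=O)N/N=C/c2c(Cl)cccc2Cl)cc(OC)c1OC` has the lowest number of the three compounds tested in a functional assay on BGC-823 cells (Homo sapiens) for antiproliferative activity, read by MTT assay, tested at 5 uM; on this read-out lower numbers stand for a weaker effect and higher numbers for a stronger effect at the one concentration tested: compound 3 gives 27.8%. Compound 1 `COc1cc(C(=O)N/N=C/c2ccc(F)c(F)c2)cc(OC)c1OC` gives 51.9%, and compound 2 `COc1cc(C(=O)N/N=C/c2ccc(C(F)(F)F)cc2)cc(OC)c1OC` gives 56.3%. Compound 4 `COc1cc(C(=O)N/N=C/c2ccccc2F)cc(OC)c1OC` differs from compound 3 in one place: 2-fluorophenyl in place of 2,6-dichlorophenyl on a carbon with a double bond to nitrogen. For the measured compounds named here, one measured step bears on this change, the one in which the 2,6-dichlorophenyl entered: a number 24.1 percentage points lower from compound 1 to compound 3 (beyond the scatter). Taking the 2,6-dichlorophenyl back out for another fluorine-bearing ring is expected to move the number upward, though compound 4 carries a 2-fluorophenyl rather than the 3,4-difluorophenyl of compound 1, so a somewhat smaller rise is estimated: a number 17.2 percentage points higher from compound 3 to compound 4 (beyond the scatter). Compound 4 is therefore expected to give 45%, between 28% and 62%.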

Compound 4, a percentage reported as inhibition, at one concentration (the size of the read-out at that concentration, not a potency): 76.5%
Compound 4: the middle estimate sits 31.5 percentage points below what was measured, and the stated range ends below it.
By their numbers in this assay, from the lowest: compound 3; then compounds 1 and 2 (each within the scatter of the next); then compound 4.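

On this carbon with a double bond to nitrogen in this assay, replacing the 2,6-dichlorophenyl with 2-fluorophenyl gives a number 48.7 percentage points higher from compound 3 to compound 4 (beyond the scatter). The 2-fluorophenyl also outdoes the 3,4-difluorophenyl, with a number 24.6 percentage points higher from compound 1 to compound 4 (beyond the scatter), so among these rings a second fluorine is not needed for a high number. Nothing measured here explains either step.

Still open, as far as these compounds go, is whether the rise from compound 3 comes from gaining the fluorine or from losing the chlorines. A plain phenyl or an aminophenyl ring at this place would help to separate these possibilities.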